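The source may report more compounds than this note shows. Statements on the series, on what has been measured and on what is new or still open speak of the compounds shown alone.

Three amides of a shared core were examined in a functional assay on the whole organism (Hindlimb, strain albino) with Mus musculus as the target, in the maximal electroshock model, with a stated time of 0.5 h; a lower number here means that less compound is needed, a higher number that more compound is needed for the effect. Compound 2 `O=C(/C=C/OC1=CC=C1)Nc1nc2ccccc2s1` gives 781 umol/kg there, and compound 1 `Cc1ccc2nc(NC(=O)/C=C/OC3=CC=C3)sc2c1` gives 505 umol/kg. The change between them is methyl in place of hydrogen on an aromatic carbon and it produced a step of a 1.5-fold lower number from compound 2 to compound 1 (0.19 log units; within the scatter). Compound 3 `COc1ccc(/C=C/C(=O)Nc2nc3ccccc3s2)cc1` carries a different side chain on the amide; how its core differs from that of compound 2 is not broken down here. In this assay compound 3 gives 435 umol/kg, a number lying within the scatter of both compound 1 and compound 2, so no order among the three compounds can be read from these values.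

Compound 4 `COc1ccc(/C=C/C(=O)Nc2nc3ccc(C)cc3s2)cc1` has not yet been measured. It differs from compound 3 by methyl in place of hydrogen on an aromatic carbon, the same change as that from compound 2 to compound 1, at a place described in identical words. Resting on the earlier step of a 1.5-fold lower number from compound 2 to compound 1 (0.19 log units; within the scatter), the expected step is a 1.3-fold lower number from compound 3 to compound 4 (0.12 log units; within the scatter), again inside the scatter. On that basis compound 4 is estimated to give about 330 umol/kg in this assay, with an expected range from 180 umol/kg to 620 umol/kg.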

Compound 4, dose for half-maximal effect: 209 umol/kg
Compound 4: middle estimate off by 1.6-fold (0.20 log units), on the high side; the measured number falls inside the stated range.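

In this assay, methyl in place of hydrogen on an aromatic carbon gave a 2.1-fold lower number from compound 3 to compound 4 (0.32 log units; beyond the scatter), a modest step. Set beside the earlier step on the other core, it cannot be told apart in size: the same change on two cores in this assay, a 1.5-fold lower number (0.19 log units; within the scatter) from compound 2 to compound 1 and a 2.1-fold lower number (0.32 log units; beyond the scatter) from compound 3 to compound 4, 1.3-fold (0.13 log units) apart, within the scatter of two such steps. Going by these compounds alone, the change thus lowered the number on both cores by a similar amount, but this rests on only two pairs and one position, and the earlier step alone lies within the scatter, so it does not show that the effect would carry over to other cores.

The compounds shown leave open whether another group at this place, such as ethyl, chlorine or an amine, would give a step of similar size. They also leave open how the same methyl change would behave on a core whose amide side chain carries a carboxylic acid or a longer chain.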